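Three methoxy groups replace a nitrile on the benzyl ether

This account rests on a few compounds, and the source may have more. Where it says the series, first, only, none or still open, it means among the compounds named here.

Compound 1, `FC(F)(F)c1ccc(CN2CCN(Cc3cc(-c4ccc(OCc5cccc(Cl)c5)cc4)on3)CC2)cc1`: 1400 nM
Compound 2, `N#Cc1cccc(COc2ccc(-c3cc(CN4CCN(Cc5ccc(C(F)(F)F)cc5)CC4)no3)cc2)c1`: 800 nM

Of the compounds shown here, two have been measured in a functional assay on MCF7 cells (Homo sapiens) for antiproliferative activity, read by sulforhodamine B assay, with a stated time of 72 h; on this read-out lower numbers stand for stronger inhibition and higher numbers for weaker inhibition. In this assay compound 1 gives 1400 nM and compound 2 gives 800 nM. Within the data shown here, the one step between them, a 1.8-fold lower number from compound 1 to compound 2 (0.24 log units; within the scatter), is within the scatter, so compound 2 stands at the lowest of the two numbers without being separable from compound 1.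

Compound 3, `COc1cc(COc2ccc(-c3cc(CN4CCN(Cc5ccc(C(F)(F)F)cc5)CC4)no3)cc2)cc(OC)c1OC`, has not yet been measured in this assay. It differs from compound 2 in one place: 3,4,5-trimethoxyphenyl in place of 3-cyanophenyl on a saturated chain carbon bound to an oxygen on an aromatic ring. Among the measured compounds shown here, the only measured step, from compound 1 to compound 2, concerns a small exchange on the same ring and moved the number little; no measured step covers the exchange of the whole ring for a differently substituted one. For the measured compounds named here, with that single step as the only guide, the expectation is for compound 3 a number near that of compound 2, with a wide range, which means an expected step of a 1.3-fold higher number from compound 2 to compound 3 (0.10 log units; within the scatter). The estimate for compound 3 in this assay is 1000 nM, expected between 250 nM and 4000 nM.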

Compound 3, half-maximal inhibitory concentration: 1800 nM
Compound 3: the middle estimate sits 1.8-fold (0.26 log units) below what was measured, and the stated range covers the measured number.
By their numbers in this assay, from the lowest: compounds 2, 1 and 3 (each within the scatter of the next, the first and the last beyond it).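

In this assay, among these compounds, this position, on a saturated chain carbon bound to an oxygen on an aromatic ring, gives the first step beyond the scatter: 3,4,5-trimethoxyphenyl in place of 3-cyanophenyl produces a 2.3-fold higher number from compound 2 to compound 3 (0.35 log units; beyond the scatter) and this step is modest in size. The same group in place of 3-chlorophenyl gives a 1.3-fold higher number from compound 1 to compound 3 (0.11 log units; within the scatter) and that step stays within the scatter, so the result separates compound 3 from compound 2 but not from compound 1. The position therefore holds a ring with three methoxy groups and the number stays close to that of the chloro compound, while the nitrile compound and the trimethoxy compound can be told apart; nothing measured on these compounds accounts for that difference.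

From the compounds shown here alone, it remains open whether all three methoxy groups are needed for the step from compound 2, since a ring carrying a single methoxy group would divide that change into smaller parts. Also open, going by these compounds, is how this position responds to something quite different, such as an unsubstituted phenyl ring, a ring bearing a carboxylic acid, or one bearing an amine.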